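This account rests on a few compounds, and the source may have more. Where it says the series, first, only, none or still open, it means among the compounds named here.

Compound 1 `COc1ccc(/C(F)=C\c2cc(OC)c(OC)c(OC)c2)cc1O` gave 28.9 nM in a functional assay on HT-29 cells (Homo sapiens) for cytotoxicity, read by sulforhodamine B assay, with a stated time of 72 h; on this read-out higher numbers stand for weaker inhibition and lower numbers for stronger inhibition. Compound 2 `COc1ccc(/C(F)=C\c2cc(OC)c(OC)c(OC)c2)cc1[N+](=O)[O-]` gave 202 nM. Compound 3 `COc1ccc(/C(F)=C(/F)c2cc(OC)c(OC)c(OC)c2)cc1O` gave 110 nM. Compound 4 `COc1ccc(/C(F)=C(/F)c2cc(OC)c(OC)c(OC)c2)cc1[N+](=O)[O-]` has not yet been measured in this assay.

The change from compound 1 to compound 2 is nitro in place of hydroxy on an aromatic carbon and it produced a 7.0-fold higher number from compound 1 to compound 2 (0.84 log units; beyond the scatter). Compound 4 arises from compound 3 by the same change, (nitro in place of hydroxy on an aromatic carbon), at the same place around it. The difference between the core of compound 1 and the core of compound 3 is not broken down here; what the two values show is that compound 1 sits at a lower number than compound 3.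

Because the change produced a 7.0-fold higher number from compound 1 to compound 2 (0.84 log units; beyond the scatter), a step of similar size is expected from compound 3 to compound 4, a 7.0-fold higher number from compound 3 to compound 4 (0.85 log units; beyond the scatter). Compound 4 is thus estimated at 770 nM, with a likely range of 300 nM to 2000 nM.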

Compound 4, half-maximal inhibitory concentration: 1310 nM
Compound 4: the middle estimate sits 1.7-fold (0.23 log units) below what was measured; the measured number falls inside the stated range.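

Putting nitro in place of hydroxy on the second core again gave a higher number in this assay, a 12-fold higher number from compound 3 to compound 4 (1.08 log units; beyond the scatter). Set beside the earlier step, the change carried over between the two cores with no difference in size that can be told apart: the same change on two cores in this assay, a 7.0-fold higher number (0.84 log units; beyond the scatter) from compound 1 to compound 2 and a 12-fold higher number (1.08 log units; beyond the scatter) from compound 3 to compound 4, 1.7-fold (0.23 log units) apart, within the scatter of two such steps. Going by these compounds alone, this rests on only two pairs in one cell assay, so it does not show that the step would hold on other cores, and it does not explain why the step occurs.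

The compounds shown leave open how other groups at this place, such as an amine or a carboxylic acid, would compare with hydroxy and nitro. They also leave open whether the step would persist in other cell lines.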